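The source may report more compounds than this note shows. Statements on the series, on what has been measured and on what is new or still open speak of the compounds shown alone.

Compound 1 `O=C1NC(=O)/C(=C/C2=Cc3ccccc3OC2)S1` gives 101000 nM. Compound 2 `CN1C(=O)S/C(=C\C2=Cc3ccccc3OC2)C1=O` gives > 100000 nM, which is a limit. Compound 3 `CC1Oc2ccc(Br)cc2C=C1/C=C1\SC(=O)NC1=O` gives 64500 nM.

All three were tested in a functional assay on MOLT-4 cells (Homo sapiens) for antiproliferative activity, read by MTT assay, with a stated time of 72 h; on this read-out higher numbers stand for weaker inhibition and lower numbers for stronger inhibition. Compound 2 differs from compound 1 by methyl in place of hydrogen on an amide-type nitrogen in a ring. The step that the limit leaves unreadable from compound 1 to compound 2 cannot be read, because of the limit of > 100000 nM in this assay, at which 1 of the 3 values shown sits. Compound 3 and compound 1 share no single counted difference; how their two cores differ is not broken down here. Their values in this assay lie within the usual scatter, so they are treated as alike.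

Compound 4 `CC1Oc2ccc(Br)cc2C=C1/C=C1\SC(=O)N(C)C1=O` has not yet been measured. It differs from compound 3 by methyl in place of hydrogen on an amide-type nitrogen in a ring, the same change as that from compound 1 to compound 2, at a place described in the same words. Going by the values given here, since the one earlier example of this change ended at a limit, its size is unknown. The step of a 2.0-fold higher number from compound 3 to compound 4 (0.30 log units; within the scatter) is expected to run toward weaker inhibition, resting on compound 1 giving 101000 nM before the same change was made. Compound 2, which carries that change, reached only a limit. Compound 4 is therefore estimated at 130000 nM, likely between 50000 nM and 350000 nM, with a real chance that this assay reports only a limit.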

Compound 4, half-maximal inhibitory concentration: > 50000 nM
Compound 4 ended at the assay's limit; the forecaster's own chance of this, stated with the estimate: 55%; the middle value is on the limit's open side.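

In this assay compound 4 gives > 50000 nM, which is a limit. The step from compound 3 to compound 4 therefore cannot be read: the limit of > 50000 nM in this assay, at which 1 of the 4 values shown sits.

The compounds shown leave open how large the change from hydrogen to methyl on the amide-type nitrogen is on either core, with compound 2 and compound 4 both ending at limits.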